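Urea-linked pyrazoles on colon cancer cells: a demethylation step

The compounds below may be only part of what the source reports. "The series", "measured", "known", "first", "only" and "open" are said of these compounds alone.

Measured compounds:
Compound 1, `O=C(Nc1cccc(-n2cc(-c3ccncc3)c(-c3ccc(Cl)c(O)c3)n2)c1)Nc1cccc(C(F)(F)F)c1`, gives 1390 nM in a functional assay on HCT-116 cells (Homo sapiens) for inhibition, read by sulforhodamine B assay, with a stated time of 48 h; on this read-out lower numbers stand for stronger inhibition of growth and higher numbers for weaker inhibition of growth.
Compound 2, `COc1cc(-c2nn(-c3cccc(NC(=O)Nc4ccc(Cl)c(Cl)c4)c3)cc2-c2ccncc2)ccc1Cl`, gives 1210 nM in this assay.

Compound 2 stands as the lower of the two numbers recorded in this assay, but its nearest neighbour is compound 1, and the gap between them lies within the scatter, so the two are not distinguishable on these data. Compound 3, `O=C(Nc1cccc(-n2cc(-c3ccncc3)c(-c3ccc(Cl)c(O)c3)n2)c1)Nc1ccc(Cl)c(Cl)c1`, has not yet been measured in this assay. It departs from compound 2 by a single change: hydrogen in place of methyl on an oxygen on an aromatic ring. Put another way, the methoxy becomes a hydroxy, and the 4-chloro-3-methoxyphenyl becomes a 4-chloro-3-hydroxyphenyl, while the dichlorophenyl urea is kept.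

Going by the values given here, no pair of measured compounds that differ only at this oxygen is available, so the size of the step cannot be read from a precedent. What the records do show is that compound 1, which carries the hydroxy form, gives 1390 nM, a number within the scatter of compound 2. The step from compound 2 to compound 3 is therefore expected to be a 1.1-fold higher number from compound 2 to compound 3 (0.03 log units; within the scatter), a change not beyond the scatter in either direction. Compound 3 is estimated at 1300 nM, with a range from 600 nM to 2800 nM.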

Compound 3, concentration for 50% growth inhibition: 1190 nM
For compound 3 the middle estimate is 1.1-fold (0.04 log units) above the measured one; the range from low to high includes it.
By their numbers in this assay, from the lowest: compounds 3, 2 and 1 (each within the scatter of the next).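

Going by these compounds alone, replacing methyl with hydrogen on an oxygen on an aromatic ring gives a 1.0-fold lower number from compound 2 to compound 3 (0.01 log units; within the scatter) in this assay, the first direct reading of this change: with the dichlorophenyl urea kept, the methoxy and hydroxy forms cannot be told apart on this read-out. The second pair holds the 4-chloro-3-hydroxyphenyl fixed and places 3,4-dichlorophenyl where 3-(trifluoromethyl)phenyl stood on an amide-type nitrogen, and it gives a 1.2-fold lower number from compound 1 to compound 3 (0.07 log units; within the scatter) in this assay, so neither single change separates these compounds from one another. No accompanying measurement bears on these results.

The compounds shown leave open whether a longer chain on this oxygen, such as ethoxy, or an amine in place of the hydroxy would give a step beyond the scatter. They also leave open whether methoxy and hydroxy would stay indistinguishable with a urea partner other than 3,4-dichlorophenyl, or on cells other than those of this assay in this account.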